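Butoxy to butylsulfanyl at the limit of the cytotoxicity read-out

The source may report more compounds than this note shows. Statements on the series, on what has been measured and on what is new or still open speak of the compounds shown alone.

In an ADME assay on MOLT-3 cells (Homo sapiens) for cytotoxicity, with a stated time of 7 days (on this read-out lower numbers stand for higher toxicity in this test and higher numbers for lower toxicity in this test), compound 1 (`Nc1nc(NC2CC2)c2ncn(/C=C3/CC3(CO)CO)c2n1`) gives > 20000 nM, which is a limit and not a number. Compound 2 (`CCCOc1nc(N)nc2c1ncn2/C=C1/CC1(CO)CO`) gives > 20000 nM, again a limit. Compound 3 (`CCCCOc1nc(N)nc2c1ncn2/C=C1/CC1(CO)CO`) gives > 20000 nM, also a limit. Compound 3 therefore stands with the other two at the limit of > 20000 nM in this assay, at which 3 of the 3 values shown sit, so no order can be read. Compound 4 (`CCCCSc1nc(N)nc2c1ncn2/C=C1/CC1(CO)CO`) carries butylsulfanyl in place of butoxy on an aromatic carbon. The nearest measured changes, a step that the two limits leave unreadable from compound 2 to compound 3 and a step that the two limits leave unreadable from compound 1 to compound 3, give no size to carry over. The step expected in this assay is therefore none beyond the scatter, with no direction favoured. The estimated change is a number no higher from compound 3 to compound 4 (the limit leaves the size open). For compound 4 the expected value is 20000 nM, with an estimated range of 8000 nM to 40000 nM.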

Compound 4, half-maximal cytotoxic concentration: > 20000 nM
Compound 4: only a limit was reported; the forecaster's own chance of this, stated with the estimate: 70%; the middle value lies on the limit itself.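

No step can be read among compound 1, compound 2, compound 3 and compound 4 in this assay, because each value is a limit: the limit of > 20000 nM in this assay, at which 4 of the 4 values shown sit.

The compounds shown leave open whether butylsulfanyl in place of butoxy changes cytotoxicity at all.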